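The compounds below may be only part of what the source reports. "The series", "measured", "known", "first", "only" and "open" are said of these compounds alone.

So far two compounds have been measured in a functional assay on B16-F10 cells (Mus musculus) for antiproliferative activity, read by MTT assay, with a stated time of 48 h (on this read-out higher numbers stand for weaker inhibition and lower numbers for stronger inhibition), and they sit within the usual scatter of each other. For the measured compounds named here, compound 1 (`COc1ccc(/C=C/c2cc(OC)cc(OC)c2/C=C/C(=O)c2ccc(Cl)c(Cl)c2)cc1`) gives 7.5 ug/mL and compound 2 (`COc1ccc(/C=C/c2cc(OC)cc(OC)c2/C=C/C(=O)c2ccc(Br)cc2)cc1`) gives 6.5 ug/mL which leaves compound 2 level with its only neighbour. Compound 3 (`COc1ccc(/C=C/c2cc(OC)cc(OC)c2/C=C/C(=O)c2ccc(N)cc2)cc1`) keeps the shared core and differs from compound 2 in one place: amino in place of bromo on an aromatic carbon sums it up, amino in place of bromo on an aromatic carbon. Going by the values given here, only one measured step bears on this, a 1.2-fold lower number from compound 1 to compound 2 (0.06 log units; within the scatter) and it swaps one halogen-bearing phenyl group for another on the carbonyl carbon. Among the compounds with values here, no measured compound carries an amino group, so that step is a weak guide. With so little to go on, no shift beyond the scatter is expected in either direction. The estimated move is a 1.1-fold higher number from compound 2 to compound 3 (0.03 log units; within the scatter) with wide uncertainty around it. For compound 3 in this assay the estimated value is 7 ug/mL with an expected range from 3 ug/mL up to 16 ug/mL as a working guess.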

Compound 3, half-maximal inhibitory concentration: 2.8 ug/mL
Beside the measured number, compound 3's estimate is 2.5-fold (0.40 log units) above it; the measured number lies below the stated range.
By their numbers in this assay, from the lowest: compound 3; then compounds 2 and 1 (each within the scatter of the next).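

In this assay, for the compounds shown here, the change from bromo to amino gives a 2.3-fold lower number from compound 2 to compound 3 (0.37 log units; beyond the scatter) and is the first step here to pass beyond the scatter, so the group on this aromatic carbon can move the number, which the exchange of one halogen-bearing phenyl group for another did not show. Setting 4-aminophenyl in place of 3,4-dichlorophenyl points the same way, with a 2.7-fold lower number from compound 1 to compound 3 (0.43 log units; beyond the scatter) and both changes remain modest in size. No measurement is available to explain the lower number seen with amino.

The compounds shown leave open whether this gain belongs to amino in particular or would also come with a hydroxyl or dimethylamino group on the same carbon. They also leave open whether amino would give a similar step elsewhere on this ring.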